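The source may hold more compounds than are shown below. What is called first, only, known or untested is meant among the compounds shown, and "the series" means these compounds.

Measured so far:
compound 1 `CCCOP(=O)(O)OCCSC(=S)N1CCCC1` — > 100000 nM
compound 2 `CCCCCCOP(=O)(O)OCCSC(=S)N1CCCCC1` — > 100000 nM

In an ADME assay on HEK293 cells (Homo sapiens) for inhibition, read by MTT assay, with stated times of 18 h and 4 h (on this read-out lower numbers stand for stronger inhibition and higher numbers for weaker inhibition), compound 1 gives > 100000 nM, which is a limit of the assay and not a number. In this assay compound 2 gives > 100000 nM, again a limit rather than a measured number. Compound 2 therefore stands only at the edge of what the assay reports, and so does compound 1; both values sit at the limit of > 100000 nM in this assay, at which 2 of the 2 values shown sit. Going by the values given here, no step between measured compounds can be counted from these two values, so nothing about the size of any structural change is known from them.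

Compound 3 `CCCCCCOP(=O)(O)OCCSC(=S)N1CCCC1` is not yet measured in this assay. It differs from compound 2 by pyrrolidin-1-yl in place of piperidin-1-yl on a thiocarbonyl carbon. Compound 1 also carries pyrrolidin-1-yl on the thiocarbonyl carbon, and it too reached only the limit. In this assay the step from compound 2 to compound 3 is expected to be a step that the limit leaves unreadable from compound 2 to compound 3, that is, none beyond the scatter. Compound 3 is expected to give 150000 nM in this assay, within the range 60000 nM to 400000 nM, most likely again as a limit.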

Compound 3, half-maximal inhibitory concentration: > 100000 nM
Compound 3 gave a limit, no number; the forecaster's own chance of this, stated with the estimate: 85%; the middle value does not contradict the limit.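

In this assay compound 3 gives > 100000 nM, a limit and not a number. Its steps from compound 1 and compound 2 therefore cannot be read: the limit of > 100000 nM in this assay, at which 3 of the 3 values shown sit.

Left open is whether pyrrolidin-1-yl in place of piperidin-1-yl on the thiocarbonyl carbon, or the propyl-for-hydrogen change on the chain, alters inhibition at all, since no compound shown gives a number.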